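Bromine position swap on the carbonyl aryl of compound 3

A few compounds are considered here, and "the series" means these few. Any claim that something is new, unique, unknown or untested is made for them only; others in the source may bear on it.

The series keeps one core and varies the aryl group on the carbonyl carbon of the amide. Compound 1 `CCc1ccc(C(=O)Nc2ccc3nc(N4CCN(CC)CC4)cc(C)c3c2)cc1` gives 3060 nM in a functional assay on MCF7 cells (Homo sapiens) for antiproliferative activity, read by MTT assay, with a stated time of 72 h; on this read-out higher numbers stand for weaker inhibition and lower numbers for stronger inhibition. Compound 2 `CCN1CCN(c2cc(C)c3cc(NC(=O)c4ccc5ccccc5n4)ccc3n2)CC1` gives 7060 nM in this assay, and compound 3 `CCN1CCN(c2cc(C)c3cc(NC(=O)c4cccc(Br)c4)ccc3n2)CC1` gives 11600 nM. Compound 3 stands highest of the three numbers: the step of a 3.8-fold higher number from compound 1 to compound 3 (0.58 log units; beyond the scatter) lies beyond the scatter, while the step of a 1.6-fold higher number from compound 2 to compound 3 (0.22 log units; within the scatter) does not, so compound 3 and compound 2 cannot be ordered against each other.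

Compound 4 `CCN1CCN(c2cc(C)c3cc(NC(=O)c4ccc(Br)cc4)ccc3n2)CC1` is the next member. The change from compound 3 is 4-bromophenyl in place of 3-bromophenyl on a carbonyl carbon. Within the data shown here, no measured step moves a substituent on this aryl ring from one position to another; the steps of a 3.8-fold higher number from compound 1 to compound 3 (0.58 log units; beyond the scatter) and a 2.3-fold higher number from compound 1 to compound 2 (0.36 log units; beyond the scatter) exchange the whole aryl group and both are modest. They show that this position tolerates changes of modest size, but give no direction for a bromine shift. The expectation for compound 4 is therefore a step of a 1.5-fold lower number from compound 3 to compound 4 (0.16 log units; within the scatter) in this assay, which is not beyond the scatter. Compound 4 is estimated at 8000 nM, with a range of 2500 nM to 25000 nM.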

Compound 4, half-maximal inhibitory concentration: 5940 nM
Compound 4: the middle estimate sits 1.3-fold (0.13 log units) above what was measured; the range from low to high includes it.
By their numbers in this assay, from the lowest: compounds 1, 4, 2 and 3 (each within the scatter of the next, the first and the last beyond it).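

In this assay, among these compounds, the step of a 2.0-fold lower number from compound 3 to compound 4 (0.29 log units; within the scatter) gives the first reading of a bromine shift on this aryl ring, and it stays within the scatter, so 3-bromophenyl and 4-bromophenyl cannot be ordered against each other on these data. Compound 4 also cannot be separated from its neighbours: neither the step of a 1.2-fold lower number from compound 2 to compound 4 (0.08 log units; within the scatter) nor the step of a 1.9-fold higher number from compound 1 to compound 4 (0.29 log units; within the scatter) leaves the scatter, whereas the step of a 3.8-fold higher number from compound 1 to compound 3 (0.58 log units; beyond the scatter) does, so only the 3-bromophenyl member stands apart from the 4-ethylphenyl member. The data on hand give no reason for any of these steps.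

Open, going by these compounds, is whether an amine or a carboxylic acid in place of the bromine on the 4-bromophenyl group would give a step beyond the scatter in this assay from compound 4. Also open, on these data alone, is whether a longer chain in place of the ethyl group of compound 1 would keep the number within the scatter of compound 1.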